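The source may report more compounds than this note shows. Statements on the series, on what has been measured and on what is new or still open speak of the compounds shown alone.

Working notes on the series. Compound 1 `COc1cc(C(=O)C2Sc3nnc(-c4cc(OC)c(OC)c(OC)c4)n3NC2c2ccco2)cc(OC)c1OC` carries a 3,4,5-trimethoxyphenyl on a carbonyl carbon of the shared core. In a functional assay on A549 cells (Homo sapiens) for cytotoxicity, read by MTT assay, with a stated time of 48 h (a lower number here means a stronger inhibitor, a higher number a weaker inhibitor), compound 1 gives 48300 nM. Compound 3 `COc1cc(-c2nnc3n2NC(c2ccco2)C(C(=O)c2ccc(F)c(F)c2)S3)cc(OC)c1OC` gives 93700 nM in this assay. For compound 2 `COc1cc(-c2nnc3n2NC(c2ccco2)C(C(=O)C2CC2)S3)cc(OC)c1OC` the read in this assay is a limit of the assay, > 100000 nM. Of the two numbers shown, compound 1 has the lowest, with compound 3 nearest; the step of a 1.9-fold higher number from compound 1 to compound 3 (0.29 log units; within the scatter) stays within the scatter, so the two cannot be ordered. The step of an at least 2.0-fold higher number from compound 1 to compound 2 (0.31 log units; beyond the scatter) is larger and rests on (the limit of > 100000 nM in this assay, at which 1 of the 3 values shown sits).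

Compound 4 `COc1cc(-c2nnc3n2NC(c2ccco2)C(C(=O)c2ccc([N+](=O)[O-])cc2)S3)cc(OC)c1OC` is not yet measured. It differs from compound 1 in one place: 4-nitrophenyl in place of 3,4,5-trimethoxyphenyl on a carbonyl carbon. Among the compounds with values here, two measured steps bear on this exchange at the same carbonyl carbon. With 3,4-difluorophenyl in place of 3,4,5-trimethoxyphenyl the step of a 1.9-fold higher number from compound 1 to compound 3 (0.29 log units; within the scatter) stayed within the scatter; with cyclopropyl in the same place the step of an at least 2.0-fold higher number from compound 1 to compound 2 (0.31 log units; beyond the scatter) ran further. A 4-nitrophenyl entering here is therefore expected to shift the number in this assay only slightly, upward if at all. The expected step is a 1.4-fold higher number from compound 1 to compound 4 (0.16 log units; within the scatter). Compound 4 is accordingly estimated at 70000 nM in this assay, within a range from 30000 nM to 150000 nM.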

Compound 4, half-maximal inhibitory concentration: > 100000 nM
Compound 4: no number, only a limit (the forecaster's own chance of this, stated with the estimate: 30%); middle value at least 1.4-fold (0.15 log units) from the limit.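

The 4-nitrophenyl on this carbonyl carbon gives a step that clears the scatter in this assay, an at least 2.0-fold higher number from compound 1 to compound 4 (0.31 log units; beyond the scatter), so an aromatic replacement for the 3,4,5-trimethoxyphenyl can also raise the number here, which the 3,4-difluorophenyl of compound 3 did not show. The two aromatic replacements still cannot be ordered, as the floor of the step of an at least 1.0-fold higher number from compound 3 to compound 4 (0.02 log units; that floor lies within the scatter) lies within the scatter, and the step between compound 2 and compound 4 cannot be read, as both values are limits of the assay. The sizes of the steps to compound 2 and compound 4 are therefore floors and not measurements: the limit of > 100000 nM in this assay, at which 2 of the 4 values shown sit.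

From the compounds shown here alone, it remains open whether any group on this carbonyl carbon brings the number clearly under that of compound 1, which gives 48300 nM in this assay; an amine, a carboxylic acid or a longer chain in this place would test that. Also open, going by these compounds, is how far the true values of compound 2 and compound 4 lie from their limits, and so whether these two replacements differ at all.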